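The source may report more compounds than this note shows. Statements on the series, on what has been measured and on what is new or still open speak of the compounds shown alone.

Working notes on the series. Compound 1 `Cc1ccc(CN2CCc3ncn(COCc4ccccc4)c3/C(=C/c3ccccc3)C2=O)cc1` and compound 2 `COc1ccc(CN2CCc3ncn(COCc4ccccc4)c3/C(=C/c3ccccc3)C2=O)cc1` share one core and differ only in the group on an aromatic carbon of the benzyl substituent. In a functional assay on A549 cells (Homo sapiens) for inhibition, read by MTT assay, with a stated time of 72 h (a lower number here means a stronger inhibitor, a higher number a weaker inhibitor), compound 1 gives 11400 nM and compound 2 gives 46800 nM. For the measured compounds named here, compound 1 thus holds the lower of the two numbers, and the only measured step in the set, a 4.1-fold higher number from compound 1 to compound 2 (0.61 log units; beyond the scatter), separates it from compound 2.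

Compound 3 `Cc1ccccc1CN1CCc2ncn(COCc3ccccc3)c2/C(=C/c2ccccc2)C1=O` is not yet measured. Its difference from compound 1 is 2-methylphenyl in place of 4-methylphenyl on a saturated chain carbon bound to an amide-type nitrogen in a ring; cut one bond further out, the change reads 4-methylbenzyl to 2-methylbenzyl, the same atoms joined differently.

Going by the values given here, no measured step moves the methyl to another aromatic carbon, so no step bears on this change directly. Among the compounds with values here, the one step that does touch this benzyl group, a 4.1-fold higher number from compound 1 to compound 2 (0.61 log units; beyond the scatter), was modest, which suggests that changes here shift the number only moderately. For compound 3 the expected step in this assay is therefore small, likely none beyond the scatter, and is written as a 1.1-fold higher number from compound 1 to compound 3 (0.06 log units; within the scatter). Compound 3 is estimated at 13000 nM, with a range from 4500 nM to 40000 nM.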

Compound 3, half-maximal inhibitory concentration: 25600 nM
For compound 3 the middle estimate is 2.0-fold (0.29 log units) below the measured one; low and high end bracket the measured number.
By their numbers in this assay, from the lowest: compound 1; then compounds 3 and 2 (each within the scatter of the next).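

Moving the methyl alone, with the same atoms joined differently, is enough to shift the number in this assay: a 2.2-fold higher number from compound 1 to compound 3 (0.35 log units; beyond the scatter). The place of the methyl on this aromatic ring therefore matters, not only the kind of group, and the step is modest and comparable in kind to the one seen earlier when methoxy replaced methyl. The 2-methylphenyl and 4-methoxyphenyl groups are not separated from each other, a 1.8-fold lower number from compound 2 to compound 3 (0.26 log units; within the scatter), while compound 1 now has a lower number than both others by steps beyond the scatter, so 4-methylphenyl is the best of these three groups in this assay, and nothing available explains the difference between the two methyl placements.

The compounds shown leave open whether methoxy responds to the same move as methyl, since only one placement of that group appears here. Going by these compounds, it also remains open how this aromatic ring tolerates a different kind of substituent, such as an amine, a carboxylic acid or a longer chain in place of the methyl.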